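Replacing the Aryl Group with 1,3-Thiazol-2-yl

The compounds below may be only part of what the source reports. "The series", "measured", "known", "first", "only" and "open" are said of these compounds alone.

Within the data shown here, in a functional assay on HOS-TE85 cells (Homo sapiens) for inhibition, read by CCK-8 assay, with a stated time of 72 h (on this read-out higher numbers stand for weaker inhibition and lower numbers for stronger inhibition), three compounds with a shared core have numbers so far. Compound 1 `COc1ccc(F)cc1N1C(=O)CSC1c1cccc(C(=O)NCCCCc2ccccc2)c1` gives 8.8 nM, compound 2 `C#Cc1cccc(N2C(=O)CSC2c2cccc(C(=O)NCCCCc3ccccc3)c2)c1` gives 149 nM, and compound 3 `CC(F)(F)c1cccc(N2C(=O)CSC2c2cccc(C(=O)NCCCCc3ccccc3)c2)c1` gives 29.1 nM, the second highest of the three.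

Compound 4 `O=C(NCCCCc1ccccc1)c1cccc(C2SCC(=O)N2c2nccs2)c1` has not yet been measured. Its difference from compound 3 is this: a group of 5 heavy atoms (3 carbon, 1 nitrogen, 1 sulfur; one five-membered aromatic ring with 2 hetero atoms) in place of a group of 10 heavy atoms (8 carbon, 2 fluorine; one six-membered aromatic ring of carbon only), on an amide-type nitrogen in a ring.

Two measured steps changed the group at this same nitrogen, and both raised the number: a 3.3-fold higher number from compound 1 to compound 3 (0.52 log units; beyond the scatter) and a 17-fold higher number from compound 1 to compound 2 (1.23 log units; beyond the scatter). A third step, a 5.1-fold lower number from compound 2 to compound 3 (0.71 log units; beyond the scatter), changed only a substituent on the aromatic carbon ring. All three compounds carry a six-membered aromatic ring of carbon only at this nitrogen, so none directly tests the five-membered ring of compound 4. With compound 2 at 149 nM as the nearest guide, a modest to large rise in the number is expected, though with wide uncertainty.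

The expected change is a 6.2-fold higher number from compound 3 to compound 4 (0.79 log units; beyond the scatter). For compound 4 the estimated value is 180 nM, with an expected range of 40 nM to 800 nM.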

Compound 4, half-maximal inhibitory concentration: > 1000 nM
Compound 4: only a limit was reported (the forecaster's own chance of this, stated with the estimate: 5%); at least 5.5-fold (0.74 log units) between middle value and limit.
By their numbers in this assay, from the lowest: compound 1; then compound 3; then compound 2. At a limit, above all of these: compound 4.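

In this assay compound 4 is reported only as a limit, not as a number: the limit of > 1000 nM in this assay, at which 1 of the 4 values shown sits. With 1,3-thiazol-2-yl in place of the aryl groups on the amide-type nitrogen, the steps are an at least 34-fold higher number from compound 3 to compound 4 (1.53 log units; beyond the scatter), an at least 6.7-fold higher number from compound 2 to compound 4 (0.82 log units; beyond the scatter) and an at least 110-fold higher number from compound 1 to compound 4 (2.05 log units; beyond the scatter). Among these compounds, the earlier compounds showed only that the number moves among six-membered aromatic rings of carbon at this nitrogen, whereas compound 4 shows that this five-membered aromatic ring with two hetero atoms gives the weakest inhibition of the four.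

The compounds shown do not separate the effect of ring size from that of the ring nitrogen and sulfur. They also leave open how an unsubstituted phenyl, a pyridin-2-yl or a thiazole carrying a methyl or methoxy group would read at this nitrogen.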